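Varying the Aryl Group on the Triazole Nitrogen

This account rests on a few compounds, and the source may have more. Where it says the series, first, only, none or still open, it means among the compounds named here.

Three compounds sharing one core differ only in the aryl group carried by a ring nitrogen of the triazole. In a functional assay on HepG2 cells (Homo sapiens) for antiproliferative activity, read by MTT assay, with a stated time of 48 h (a higher number here means a weaker inhibitor, a lower number a stronger inhibitor), compound 1 `N#CC1=C(N)Oc2c(N)cc3nc4ccccc4nc3c2C12C(=O)N(Cc1cnnn1-c1ccccc1Cl)c1ccccc12` gives 33500 nM. In this assay compound 2 `N#CC1=C(N)Oc2c(N)cc3nc4ccccc4nc3c2C12C(=O)N(Cc1cnnn1-c1cccc(C(F)(F)F)c1)c1ccccc12` gives 15800 nM, and compound 3 `N#CC1=C(N)Oc2c(N)cc3nc4ccccc4nc3c2C12C(=O)N(Cc1cnnn1-c1c(Cl)cc(Cl)cc1Cl)c1ccccc12` gives 37800 nM. Compound 3 thus stands at the highest number of the three, though the step of a 1.1-fold higher number from compound 1 to compound 3 (0.05 log units; within the scatter) lies within the scatter, so compound 1 and compound 3 cannot be ordered. The steps of a 2.1-fold lower number from compound 1 to compound 2 (0.33 log units; beyond the scatter) and a 2.4-fold higher number from compound 2 to compound 3 (0.38 log units; beyond the scatter) are modest but beyond the scatter.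

The unmeasured compound 4 `COc1cc(-n2nncc2CN2C(=O)C3(C(C#N)=C(N)Oc4c(N)cc5nc6ccccc6nc5c43)c3ccccc32)c(OC)cc1Cl` carries the change (4-chloro-2,5-dimethoxyphenyl in place of 2,4,6-trichlorophenyl on an aromatic nitrogen). All three measured steps bear on this change, since each also swaps one aryl group for another on the same nitrogen, and none of them moved the number by more than a modest amount in either direction. A change of the same kind is therefore expected to produce at most a modest step in this assay, and since the measured numbers cluster around compound 1 and compound 3, the direction is expected to be toward a somewhat lower number.

Compound 4 is therefore estimated to give 25000 nM in this assay, within a range from 9000 nM to 60000 nM. The expected step of a 1.5-fold lower number from compound 3 to compound 4 (0.18 log units; within the scatter) would stay modest.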

Compound 4, half-maximal inhibitory concentration: > 50000 nM
Compound 4: a limit, no number; the forecaster's own chance of this, stated with the estimate: 5%; at least 2.0-fold (0.30 log units) between middle value and limit.
By their numbers in this assay, from the lowest: compound 2; then compounds 1 and 3 (each within the scatter of the next). At a limit, above all of these: compound 4.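

Compound 4 has no number in this assay, only a limit of the assay: the limit of > 50000 nM in this assay, at which 1 of the 4 values shown sits.

Even so, the limit gives this nitrogen its widest step so far, an at least 3.1-fold higher number from compound 2 to compound 4 (0.50 log units; beyond the scatter), which exceeds every step among the three earlier aryl groups and places 4-chloro-2,5-dimethoxyphenyl clearly apart from 3-(trifluoromethyl)phenyl. Going by these compounds alone, the other two comparisons, an at least 1.3-fold higher number from compound 3 to compound 4 (0.12 log units; that floor lies within the scatter) and an at least 1.4-fold higher number from compound 1 to compound 4 (0.17 log units; that floor lies within the scatter), have floors within the scatter, so the limit does not clearly separate compound 4 from either compound and shows only that the chlorinated aryl groups of compound 1 and compound 3 and the dimethoxy group of compound 4 may lie close together or far apart.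

The compounds shown leave open whether the two methoxy groups or the altered placement of chlorine accounts for the gap to compound 2, and the exact value of compound 4 remains unknown. Also open, as far as these compounds go, is how this nitrogen responds to an aryl group carrying an amine, a carboxylic acid or a single methoxy group, and whether any such group would give a lower number than compound 2.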